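A few compounds are considered here, and "the series" means these few. Any claim that something is new, unique, unknown or untested is made for them only; others in the source may bear on it.

Of the compounds shown here, three built on one shared core have been measured in an assay on HEK293 cells for inhibition of Voltage-dependent N-type calcium channel subunit alpha-1B (Homo sapiens), read by patch clamp, using a membrane potential dye; on this read-out higher numbers stand for weaker inhibition and lower numbers for stronger inhibition. Compound 1 `COc1ccccc1-n1nc(C2CC(C)(C)OC(C)(C)C2)cc1-c1ccc(C#N)cc1` gives 85 nM. Among the compounds with values here, compound 2 `CCOc1ccc(-c2cc(C3CC(C)(C)OC(C)(C)C3)nn2-c2ccccc2OC)cc1` gives 29 nM; the one measured step, a 2.9-fold lower number from compound 1 to compound 2 (0.47 log units; beyond the scatter), comes from putting ethoxy in place of cyano on an aromatic carbon. Compound 3 `COc1ccccc1-n1nc(C2CCOC(C)(C)C2)cc1-c1ccc(Cl)cc1` gives 55 nM, the second highest of the three numbers: compound 1 is its nearest neighbour and compound 2 its furthest, and both gaps lie within the usual scatter. Compound 1 and compound 3 differ in two places at once, so their values show only that they sit within the scatter of each other.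

Compound 4 `COc1ccccc1-n1nc(C2=CC(C)(C)OC(C)(C)C2)cc1-c1ccc(Cl)cc1` is not yet measured. It differs from compound 3 in one place: a group of 10 heavy atoms (9 carbon, 1 oxygen; one six-membered non-aromatic ring with 1 hetero atom) in place of a group of 8 heavy atoms (7 carbon, 1 oxygen; one six-membered non-aromatic ring with 1 hetero atom), on an aromatic carbon. Within the data shown here, no measured step touches this part of the molecule; the step from compound 1 to compound 2 concerns the other aromatic ring, and neither compound 1 nor compound 2 carries a ring with a double bond outside aromatic rings. The numbers therefore give no direct guide, and compound 4 is expected to show a 1.1-fold lower number from compound 3 to compound 4 (0.04 log units; within the scatter), a step not beyond the scatter. On that basis compound 4 is estimated at 50 nM, within a range from 18 nM to 140 nM.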

Compound 4, half-maximal inhibitory concentration: 26000 nM
Estimate against measurement, compound 4: 520-fold (2.72 log units) below; measured number above the stated range.
By their numbers in this assay, from the lowest: compounds 2, 3 and 1 (each within the scatter of the next, the first and the last beyond it); then compound 4.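

In this assay, replacing 2,2-dimethyloxan-4-yl with the larger ring carrying 1 double bond outside aromatic rings, on the aromatic carbon two ring bonds from the ring atom that bears the 4-chlorophenyl group, gives a 470-fold higher number from compound 3 to compound 4 (2.67 log units; beyond the scatter), so this position does not accept every six-membered non-aromatic ring with 1 hetero atom. Within the data shown here, the earlier compounds could not show this, as the only step among them lay on the other aromatic ring, where a 2.9-fold lower number from compound 1 to compound 2 (0.47 log units; beyond the scatter) is far smaller, and this single change at the pyrazole-side position now outweighs it. Nothing measured here bears on the reason for this much weaker inhibition.

The change adds heavy atoms and a double bond together, and no compound shown carries either alteration alone on the same 4-chlorophenyl group, so the share of each in the step stays open. As far as these compounds go, what a piperidin-4-yl group, a carboxylic acid or a simple open chain such as ethyl would give on this aromatic carbon also remains open.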